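Adding a bromo group to compound 3

The source may report more compounds than this note shows. Statements on the series, on what has been measured and on what is new or still open speak of the compounds shown alone.

compound 1 (`COC1=C(C)C(=O)/C(=C(O)/C=C/c2ccc(F)cc2)C(=O)C1(C)C`) gives 3.7 ug/mL
compound 2 (`COC1=C(C)C(=O)/C(=C(O)/C=C/c2cccc3ccccc23)C(=O)C1(C)C`) gives 2.8 ug/mL
compound 3 (`CCCC1=C(OC)C(CCC)(CCC)C(=O)/C(=C(O)\C=C\c2ccccc2)C1=O`) gives 0.6 ug/mL

Compound 3 at 0.6 ug/mL has the lowest of the three numbers in a functional assay on KB cells (Homo sapiens) for cytotoxicity (on this read-out lower numbers stand for an effect already at smaller amounts and higher numbers for an effect only at larger amounts of compound), and stands beyond the usual scatter from both other compounds. Compound 4 (`CCCC1=C(OC)C(CCC)(CCC)C(=O)/C(=C(O)\C=C\c2ccc(Br)cc2)C1=O`) differs from compound 3 by bromo in place of hydrogen on an aromatic carbon, para to a large group (bromo in place of hydrogen on an aromatic carbon). Among the measured compounds shown here, no two measured compounds differ in one place only, so nothing here shows directly what this swap does. With the rest of compound 3 unchanged, the expectation starts from its 0.6 ug/mL and foresees no step beyond the scatter in this assay in either direction. The estimated step is a 1.2-fold higher number from compound 3 to compound 4 (0.07 log units; within the scatter) and so stays small. For compound 4 the estimated value is 0.7 ug/mL with an expected range from 0.25 ug/mL to 2 ug/mL in this measurement.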

Compound 4, concentration for half-maximal effect: 0.9 ug/mL
Compound 4: middle estimate off by 1.3-fold (0.11 log units), on the low side, and the stated range covers the measured number.
By their numbers in this assay, from the lowest: compounds 3 and 4 (each within the scatter of the next); then compounds 2 and 1 (each within the scatter of the next).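

Among the compounds shown here, this is the first pair of compounds that differ in one place only. In this assay, bromo in place of hydrogen on an aromatic carbon, para to a large group, gives a 1.5-fold higher number from compound 3 to compound 4 (0.18 log units; within the scatter) and so stays within the usual scatter, which shows that this position accepts a bromine atom without a clear shift in the read-out. No measurement here explains this result.

The compounds shown leave open whether an amine or a carboxylic acid at this same place would also stay within the scatter.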